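The compounds below may be only part of what the source reports. "The series", "measured", "known", "first", "only" and "open" are said of these compounds alone.

Among the compounds with values here, in a functional assay on LS174T cells (Homo sapiens) for inhibition, read by MTT assay, with a stated time of 72 h (a higher number here means a weaker inhibitor, a lower number a stronger inhibitor), compound 1 (`CCc1ccc(C(=O)/C=C/C(=O)O)cc1`) gives 21000 nM as the highest of the three numbers so far, which makes it the weakest inhibitor of the measured set. Compound 2 (`CC(C)c1cc(C(C)C)c(C(=O)/C=C/C(=O)O)c(C(C)C)c1`) reads 8280 nM and compound 3 (`O=C(O)/C=C/C(=O)c1cc(C2CCCCC2)ccc1C1CCCCC1`) reads 4280 nM with each lying lower than compound 1 by more than the scatter. Within the data shown here, no two measured compounds differ in one place only, so no direct step is available as a guide.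

Next is compound 4 (`O=C(O)/C=C/C(=O)c1ccc(F)cc1`), which carries fluoro in place of ethyl on an aromatic carbon, para to a group of 7 heavy atoms. The only trend on hand is thin: compound 1 with 21000 nM as its value carries less carbon on the ring than compound 2 or compound 3. Among the measured compounds shown here, no measured compound goes against that reading, though three compounds settle little. Fluoro leaves no carbon at that place, so in this assay a small move toward a higher number is expected. The estimated step is a 1.4-fold higher number from compound 1 to compound 4 (0.15 log units; within the scatter) and it is expected to stay within the scatter. For compound 4 the expected value is 30000 nM with 12000 nM to 70000 nM as its estimated range.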

Compound 4, half-maximal inhibitory concentration: 33800 nM
Compound 4: middle estimate off by 1.1-fold (0.05 log units), on the low side; the range from low to high includes it.
By their numbers in this assay, from the lowest: compounds 3 and 2 (each within the scatter of the next); then compounds 1 and 4 (each within the scatter of the next).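

In this assay, within the data shown here, the exchange of ethyl for fluoro on an aromatic carbon, para to a group of 7 heavy atoms, gives a 1.6-fold higher number from compound 1 to compound 4 (0.21 log units; within the scatter) and provides the first comparison that isolates one place on the shared core. At this position, ethyl and fluoro therefore cannot be told apart in this read-out, even though the entering group has no carbon and fewer heavy atoms than the one it replaces. No measurement here bears on why the two compounds read alike.

As far as these compounds go, it remains open whether a group of another kind at the same place, such as an amine, a methoxy group or a longer chain like butyl, would give a step beyond the scatter from the core of compound 1. Also open, from the compounds shown here alone, is whether the same exchange of ethyl for fluoro would stay within the scatter elsewhere on the ring, or whether an amide in place of the carboxylic acid would shift the number for either compound.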